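Nitrile position on the aryl of the benzimidazole series

This account rests on a few compounds, and the source may have more. Where it says the series, first, only, none or still open, it means among the compounds named here.

Measured so far:
compound 1 `CN1CCN(CCCN(c2nc3cc(Cl)c(Cl)cc3[nH]2)[C@@H]2CC[C@]3(c4cccc(C#N)c4)C[C@H]23)CC1` — 6.8 nM
compound 2 `CN1CCN(CCCN(c2nc3cc(F)c(F)cc3[nH]2)[C@@H]2CC[C@]3(c4cccc(C#N)c4)C[C@H]23)CC1` — 20.7 nM

Among the measured compounds shown here, in an assay on isolated protein for binding affinity to melanin-concentrating hormone receptor 1 (Homo sapiens) (on this read-out higher numbers stand for weaker inhibition and lower numbers for stronger inhibition), compound 1 gives 6.8 nM, the lowest of the two numbers; the only other measured compound, compound 2, sits at a 3.0-fold higher number from compound 1 to compound 2 (0.48 log units; beyond the scatter). Compound 3 `CN1CCN(CCCN(c2nc3cc(Cl)c(Cl)cc3[nH]2)[C@@H]2CC[C@]3(c4ccc(C#N)cc4)C[C@H]23)CC1` is not yet measured. It differs from compound 1 by 4-cyanophenyl in place of 3-cyanophenyl on a saturated ring carbon. For the measured compounds named here, no measured step touches this aryl group; the one step known concerns the benzimidazole halogens, so it gives no guide here. With nothing to lean on, compound 3 is expected to stay near compound 1, with a wide range: 12 nM (from 3 nM to 50 nM), i.e. an expected 1.8-fold higher number from compound 1 to compound 3 (0.25 log units; within the scatter).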

Compound 3, inhibition constant: 11.4 nM
Compound 3: middle estimate off by 1.1-fold (0.02 log units), on the high side; measured number inside the range.
By their numbers in this assay, from the lowest: compounds 1, 3 and 2 (each within the scatter of the next, the first and the last beyond it).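

Placing the nitrile as 4-cyanophenyl rather than 3-cyanophenyl gives in this assay a 1.7-fold higher number from compound 1 to compound 3 (0.22 log units; within the scatter) with the dichloro benzimidazole held constant, so this read-out does not separate the two nitrile placements. Among the compounds shown here, this is the first reading on the aryl group, as the earlier step concerned only the benzimidazole halogens. Nothing available accounts for this result.

Going by these compounds, whether the nitrile itself matters stays open, and an unsubstituted phenyl or a methoxyphenyl would test that. Also unsettled is whether 4-cyanophenyl behaves alike with 5,6-difluoro-1H-benzimidazol-2-yl.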